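The source may report more compounds than this note shows. Statements on the series, on what has been measured and on what is new or still open speak of the compounds shown alone.

Compound 3 `Cc1c(Nc2nc(N)c3c(C#N)c(N4CCC[C@H]4C)n(C)c3n2)cnn1CC1(O)COC1` gives 16 nM in an assay on isolated protein for inhibition of Leucine-rich repeat serine/threonine-protein kinase 2 (Homo sapiens), read by TR-FRET and LanthaScreen, with stated times of 50 min and 30 min, in the presence of a further agent that is not named here (on this read-out lower numbers stand for stronger inhibition and higher numbers for weaker inhibition), the lowest of the three numbers recorded there. Its nearest neighbour is compound 1 `Cc1c(Nc2nc(N)c3c(C#N)c(N4CCC[C@H]4C)n(C)c3n2)cnn1C`, which gives 75 nM in this assay, and furthest from it is compound 2 `Cn1c(N2CCCC2)c(C#N)c2c(N)ncnc21`, which gives 1480 nM. Among the compounds with values here, the one single-point step recorded runs from compound 1 to compound 3 and reads a 4.7-fold lower number from compound 1 to compound 3 (0.67 log units; beyond the scatter); that step added the 3-hydroxyoxetan-3-yl group on a saturated chain carbon bound to an aromatic nitrogen.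

Compound 4 `Cc1c(Nc2nc(N)c3c(C#N)c(N4CCC[C@H]4C)n(C)c3n2)cnn1CC(C)(C)O` differs from compound 3 at that same place: 1-hydroxy-1-methylethyl in place of 3-hydroxyoxetan-3-yl on a saturated chain carbon bound to an aromatic nitrogen. Within the data shown here, no measured pair shows this exchange of one hydroxylated group for another, so the only guidance is that the hydroxyoxetanyl group, when added to compound 1, brought a modest gain. Keeping a hydroxyl-bearing group of similar size at the same position suggests that most of that gain is retained, with perhaps a slight loss as the ring is opened.

The step from compound 3 to compound 4 in this assay is therefore expected to be small, a 1.6-fold higher number from compound 3 to compound 4 (0.19 log units; within the scatter), within or just beyond the scatter. Compound 4 is estimated at 25 nM, with a range from 10 nM to 60 nM.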

Compound 4, half-maximal inhibitory concentration: 43 nM
Estimate against measurement, compound 4: 1.7-fold (0.24 log units) below; measured number inside the range.
By their numbers in this assay, from the lowest: compound 3; then compounds 4 and 1 (each within the scatter of the next); then compound 2.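

In this assay, the exchange at this position gives a 2.7-fold higher number from compound 3 to compound 4 (0.43 log units; beyond the scatter), so the two hydroxylated groups are not interchangeable here, even though each carries one hydrogen-bond donor; 3-hydroxyoxetan-3-yl differs from 1-hydroxy-1-methylethyl in its four-membered ring and its additional hydrogen-bond acceptor. The second new step, a 1.7-fold lower number from compound 1 to compound 4 (0.24 log units; within the scatter), shows that placing 1-hydroxy-1-methylethyl on this saturated chain carbon bound to an aromatic nitrogen does not separate compound 4 from compound 1, whereas a 4.7-fold lower number from compound 1 to compound 3 (0.67 log units; beyond the scatter) does separate compound 3 from compound 1, so a hydroxylated group at this place does not by itself bring the gain. No supporting measurement is available to explain why the two groups part in this way.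

The compounds shown leave open whether the gain depends on the ring, the ring oxygen or the hydroxyl, which a 1-hydroxycyclobutyl group, with carbon in place of the ring oxygen, or an oxetan-3-yl group without the hydroxyl could begin to separate. They also leave open whether the difference between the two groups would persist with an amine other than the methyl-substituted ring on the shared core.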